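This account rests on a few compounds, and the source may have more. Where it says the series, first, only, none or still open, it means among the compounds named here.

Compound 1 `OCc1cccc(C2=NCCCC2)c1` gives 35000 nM in an assay on cell membranes for displacement of a labelled ligand from Neuronal acetylcholine receptor; alpha4/beta2 (Rattus norvegicus), read by radioligand binding, with a stated time of 30 min (a lower number here means a stronger inhibitor, a higher number a weaker inhibitor), the highest of the two numbers measured; its nearest neighbour, compound 2 `c1ccc(C2=NCCCC2)cc1`, gives 2080 nM. Within the data shown here, the only step seen so far, a 17-fold lower number from compound 1 to compound 2 (1.23 log units; beyond the scatter), removes the hydroxymethyl altogether. Compound 3 `Clc1cccc(C2=NCCCC2)c1` instead carries chloro in place of hydroxymethyl on an aromatic carbon, meta to a group of 6 heavy atoms. With the hydroxymethyl gone again, a step of similar direction is expected, roughly a 23-fold lower number from compound 1 to compound 3 (1.37 log units; beyond the scatter). Compound 3 is therefore estimated at 1500 nM, within 400 nM to 6000 nM.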

Compound 3, inhibition constant: 11500 nM
For compound 3 the middle estimate is 7.7-fold (0.88 log units) below the measured one; the whole stated range lies below it.
By their numbers in this assay, from the lowest: compound 2; then compound 3; then compound 1.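

Replacing the hydroxymethyl with chloro on this aromatic carbon still lowers the number (a 3.0-fold lower number from compound 1 to compound 3 (0.48 log units; beyond the scatter)), so the direction seen on removing the hydroxymethyl holds for a second replacement. Chloro does not match plain hydrogen, however (a 5.5-fold higher number from compound 2 to compound 3 (0.74 log units; beyond the scatter)), so with hydroxymethyl and chloro alike, compound 2, with hydrogen there, keeps the lowest number of the three. Nothing given here explains these differences. On these data alone, whether an amine, a methoxy or a longer chain on this carbon would also sit above compound 2 remains open. So does how chloro would behave on another carbon of the ring.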